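Changing the group on the carbonyl carbon

The source may report more compounds than this note shows. Statements on the series, on what has been measured and on what is new or still open speak of the compounds shown alone.

Two compounds share a core and differ only in the group attached to the carbonyl carbon. Compound 1 `O=C(c1ccccc1)N(/N=N/c1ccc([N+](=O)[O-])cc1Cl)c1ccc([N+](=O)[O-])cc1Cl` carries a plain phenyl there; in a functional assay on HeLa cells (Homo sapiens) for cytotoxicity, read by MTT assay, with a stated time of 72 h (a higher number here means a weaker inhibitor, a lower number a stronger inhibitor), compound 1 gives 590 nM. Going by the values given here, compound 2 `O=C(c1ccc(C(F)(F)F)cc1)N(/N=N/c1ccc([N+](=O)[O-])cc1Cl)c1ccc([N+](=O)[O-])cc1Cl` carries a 4-(trifluoromethyl)phenyl instead; in this assay compound 2 gives 1060 nM, the higher of the two numbers measured so far, although the step of a 1.8-fold higher number from compound 1 to compound 2 (0.25 log units; within the scatter) lies within the scatter. Compound 3 `O=C(c1cccc(F)c1)N(/N=N/c1ccc([N+](=O)[O-])cc1Cl)c1ccc([N+](=O)[O-])cc1Cl` has not yet been measured. It differs from compound 2 by 3-fluorophenyl in place of 4-(trifluoromethyl)phenyl on a carbonyl carbon. Among the compounds with values here, the only measured step that bears on this change is a 1.8-fold higher number from compound 1 to compound 2 (0.25 log units; within the scatter), which was small; removing the trifluoromethyl group might bring the number back toward that of compound 1, while the added fluorine has no measured precedent here. The expected step of a 1.5-fold lower number from compound 2 to compound 3 (0.18 log units; within the scatter) is therefore small, most likely a slightly lower number within the scatter. Compound 3 is estimated to give 700 nM in this assay, with a range from 300 nM to 1600 nM.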

Compound 3, half-maximal inhibitory concentration: 2500 nM
The estimate for compound 3 lay 3.6-fold (0.55 log units) below the measured number; measured number above the stated range.
By their numbers in this assay, from the lowest: compounds 1 and 2 (each within the scatter of the next); then compound 3.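

In this assay the aryl group on the carbonyl carbon proves able to shift the number beyond the scatter: fluoro in place of hydrogen brings a 4.2-fold higher number from compound 1 to compound 3 (0.63 log units; beyond the scatter) while the earlier trifluoromethyl step, a 1.8-fold higher number from compound 1 to compound 2 (0.25 log units; within the scatter), did not. Replacing 4-(trifluoromethyl)phenyl with 3-fluorophenyl brings a 2.4-fold higher number from compound 2 to compound 3 (0.37 log units; beyond the scatter) and leaves compound 3 as the weakest inhibitor of the three. Nothing available explains why this fluorine-bearing ring gives the highest number.

The groups in compound 2 and compound 3 differ both in kind and in where they sit on the ring, as their names show, so these compounds cannot separate those two changes. On these data alone, whether a methoxy group, an amine or a carboxylic acid on this ring would raise or lower the number remains open.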